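This account rests on a few compounds, and the source may have more. Where it says the series, first, only, none or still open, it means among the compounds named here.

Compound 1 `CNC(=O)c1cccc(S(=O)(=O)Oc2ccc(-c3cncn3C3CCN(C(=O)c4ccc(Cl)c(C(F)(F)F)c4)CC3)cc2)c1` — 112 nM
Compound 2 `CN(C)c1ccc(C(=O)N2CCC(n3cncc3-c3ccc(OS(=O)(=O)c4cccc5cnccc45)cc3)CC2)cc1` — 0.11 nM
Compound 3 `CNC(=O)c1cccc(S(=O)(=O)Oc2ccc(-c3cncn3C3CCN(C(=O)c4ccc(N(C)C)cc4)CC3)cc2)c1` — 25 nM

In an assay on HEK293 cells for antagonist activity at P2X purinoceptor 7 (Homo sapiens), read by fluorescence, with a stated time of 2 h (a lower number here means a stronger inhibitor, a higher number a weaker inhibitor), compound 3 holds the second highest of the three numbers. Its nearest neighbour is compound 1, reached by a 4.5-fold lower number from compound 1 to compound 3 (0.65 log units; beyond the scatter); its furthest is compound 2, reached by a 230-fold higher number from compound 2 to compound 3 (2.36 log units; beyond the scatter). Both of these steps alter an aryl group, one on the carbonyl carbon and one on the sulfonyl sulfur.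

Compound 4 `CN(C)c1ccc(C(=O)N2CCC(n3cncc3-c3ccc(OS(=O)(=O)c4cccc(C(=O)NC5CC5)c4)cc3)CC2)cc1` differs from compound 3 in another place: cyclopropyl in place of methyl on an amide-type nitrogen. Neither measured step touches this amide-type nitrogen, so the set gives no direct guide to how this change will read in this assay. The two known steps show that the aryl groups at either end move the number strongly, but a small growth on the amide nitrogen lies outside what has been tested. The expectation for compound 4 is therefore a step of no change at the digits printed from compound 3 to compound 4 (within the scatter), not beyond the scatter. Compound 4 is estimated at 25 nM, within 8 nM to 80 nM.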

Compound 4, half-maximal inhibitory concentration: 0.49 nM
The estimate for compound 4 lay 51-fold (1.71 log units) above the measured number, outside the stated range (below it).
By their numbers in this assay, from the lowest: compound 2; then compound 4; then compound 3; then compound 1.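

In this assay, within the data shown here, the amide-type nitrogen proves to be a sensitive place, since cyclopropyl in place of methyl gives a 51-fold lower number from compound 3 to compound 4 (1.71 log units; beyond the scatter) and so a large step from a small growth, at a place the earlier steps did not touch. The 3-(cyclopropylcarbamoyl)phenyl group also brings the compound much nearer to the isoquinolin-5-yl group on the sulfonyl sulfur, leaving a 4.5-fold higher number from compound 2 to compound 4 (0.65 log units; beyond the scatter) as a modest gap where the 3-(methylcarbamoyl)phenyl group left a large one. Nothing in the data at hand accounts for this gain.

Going by these compounds, whether it belongs to the three-membered ring itself, or would also come with an ethyl, isopropyl or cyclobutyl group on this nitrogen, stays open, as does the reading of a primary amide. Also open, on these data alone, is whether cyclopropyl here would give a similar step alongside the 4-chloro-3-(trifluoromethyl)phenyl group on the carbonyl carbon.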